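A few compounds are considered here, and "the series" means these few. Any claim that something is new, unique, unknown or untested is made for them only; others in the source may bear on it.

Three related amides have been tested in a functional assay on MDA-MB-231 cells (Homo sapiens) for antiproliferative activity, read by sulforhodamine B assay; a higher number here means a weaker inhibitor of growth, a lower number a stronger inhibitor of growth. Compound 1 `COc1ccc(C(=O)Nc2nc3cc(C)cc(C)c3s2)cc1` gives 1.03 ug/mL. Compound 2 `Cc1cc(C)c2sc(NC(=O)c3ccc(C#N)cc3)nc2c1` gives 0.48 ug/mL. Compound 3 `COc1ccc(C(=O)Nc2nc3c(OC)cccc3s2)cc1` gives 1.25 ug/mL, which sits within the scatter of compound 1 and differs from compound 2 by more than the scatter.

Compounds 1 and 2 differ in one place: cyano in place of methoxy on an aromatic carbon. That single change gave a 2.1-fold lower number from compound 1 to compound 2 (0.33 log units; beyond the scatter), a modest step toward stronger growth inhibition.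

Compound 3 carries the same methoxy-bearing amide as compound 1 but a different core; the difference between the two cores is not broken down here. Compound 4 `COc1cccc2sc(NC(=O)c3ccc(C#N)cc3)nc12` is the not yet measured partner of compound 3, and it differs from compound 3 by cyano in place of methoxy on an aromatic carbon. Among the measured compounds shown here, this is the same change, at the same place, as the one made from compound 1 to compound 2, now applied on the core of compound 3.

For the measured compounds named here, with only one earlier instance of this change, the expectation for compound 4 rests on that single step. In this assay compound 4 is expected to show a 2.1-fold lower number from compound 3 to compound 4 (0.32 log units; beyond the scatter), close to the earlier step of a 2.1-fold lower number from compound 1 to compound 2 (0.33 log units; beyond the scatter), because compound 3 gives 1.25 ug/mL as the starting point and nothing among the three measured compounds suggests the new core would alter the effect of the change. The estimated value for compound 4 is therefore 0.6 ug/mL, with a likely range from 0.3 ug/mL to 1.2 ug/mL.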

Compound 4, concentration for 50% growth inhibition: > 10 ug/mL
Compound 4: only a limit was reported; the forecaster's own chance of this, stated with the estimate: 0%; middle value at least 16-fold (1.22 log units) from the limit.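

In this assay compound 4 gives > 10 ug/mL, which is a limit of the assay and not a number: the limit of > 10 ug/mL in this assay, at which 1 of the 4 values shown sits. Even with only a limit, the direction can be read, with an at least 8.0-fold higher number from compound 3 to compound 4 (0.90 log units; beyond the scatter), so cyano in place of methoxy did not carry over from one core to the other, and the two steps run in opposite directions: the same change on two cores in this assay, a 2.1-fold lower number (0.33 log units; beyond the scatter) from compound 1 to compound 2 and an at least 8.0-fold higher number (0.90 log units; beyond the scatter) from compound 3 to compound 4, at least 17-fold (1.23 log units) apart, beyond the scatter of two such steps. This shows that, for this pair of cores, the effect of the change depends on the core that carries it, so a step measured on one core was a poor guide to the same step on the other; it does not show which feature of the cores is responsible, how far compound 4 lies past the limit, or how the change would behave on any third core.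

The compounds shown carry only methoxy or cyano at the changed place, so it remains open how a group such as an amine or a carboxylic acid there would behave on each of the two cores. From the compounds shown here alone, it also remains open whether a core bearing a different group, such as chlorine or an ethyl chain, would follow compound 1 and compound 2 or compound 3 and compound 4.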